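The source may report more compounds than this note shows. Statements on the series, on what has been measured and on what is new or still open speak of the compounds shown alone.

Two compounds have been measured in a functional assay on A549 cells (Homo sapiens) for antiproliferative activity, read by CCK-8 assay, with a stated time of 72 h; a higher number here means a weaker inhibitor, a lower number a stronger inhibitor:
compound 1 `COc1cccc(C(=O)Nc2cccc(-c3oc4cc(-c5ccc(F)cc5)ccc4c(=O)c3O)c2)c1`, which gives 10800 nM;
compound 2 `Cc1cc(C)cc(C(=O)Nc2cccc(-c3oc4cc(-c5ccc(F)cc5)ccc4c(=O)c3O)c2)c1`, which gives 3740 nM.

Going by the values given here, of these two numbers, compound 2 holds the lower one, and the only step measured so far, a 2.9-fold lower number from compound 1 to compound 2 (0.46 log units; beyond the scatter), is of modest size. Compound 3 `O=C(Nc1cccc(-c2oc3cc(-c4ccc(F)cc4)ccc3c(=O)c2O)c1)c1ccc(Cl)nc1` has not yet been measured. It differs from compound 2 in one place: 6-chloropyridin-3-yl in place of 3,5-dimethylphenyl on a carbonyl carbon. Among the compounds with values here, no measured pair shows a 6-chloropyridin-3-yl group entering at this carbonyl carbon; the one step available at that position, the exchange of 3-methoxyphenyl for 3,5-dimethylphenyl, moved the number only modestly. A further exchange of the ring on the carbonyl carbon is expected to shift this assay by a modest amount at most, and the direction cannot be read from two numbers alone; a value between those of compound 1 and compound 2 seems the most plausible outcome. Compound 3 is therefore expected to give about 6000 nM, within 2500 nM to 15000 nM, which would mean an estimated step of a 1.6-fold higher number from compound 2 to compound 3 (0.21 log units; within the scatter).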

Compound 3, half-maximal inhibitory concentration: 3580 nM
Beside the measured number, compound 3's estimate is 1.7-fold (0.22 log units) above it; low and high end bracket the measured number.
By their numbers in this assay, from the lowest: compounds 3 and 2 (each within the scatter of the next); then compound 1.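

In this assay, putting 6-chloropyridin-3-yl in place of 3,5-dimethylphenyl on the carbonyl carbon gives a 1.0-fold lower number from compound 2 to compound 3 (0.02 log units; within the scatter) and so leaves the two compounds indistinguishable, even though the entering ring brings nitrogen, chlorine and a hydrogen-bond acceptor that the leaving ring lacks. Set against 3-methoxyphenyl, the same group gives a 3.0-fold lower number from compound 1 to compound 3 (0.48 log units; beyond the scatter) and so, of these three compounds, only compound 1 stands apart, with the higher number. No measured property of these groups is available to account for this result.

Going by these compounds, all three compounds carry an aromatic ring on this carbonyl carbon, so the effect of a saturated ring such as cyclohexyl, a small group such as methyl, or a ring bearing an amine or a carboxylic acid remains open. The chlorine and the ring nitrogen also enter together in compound 3, and their separate contributions could be read only from a compound such as the plain pyridin-3-yl amide or the 4-chlorophenyl amide.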